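Exchanging the group on the carbonyl carbon

A few compounds are considered here, and "the series" means these few. Any claim that something is new, unique, unknown or untested is made for them only; others in the source may bear on it.

Compound 1 `Cc1nc(S(C)(=O)=O)ccc1Oc1ncnc(OC2CCN(C(=O)OC(C)(C)CF)CC2)c1F` gives 19.9 nM in a functional assay on isolated protein for inhibition of Glucose-dependent insulinotropic receptor (Homo sapiens), read by HTRF and cAMP accumulation; a lower number here means that less compound is needed, a higher number that more compound is needed for the effect. Compound 2 `Cc1nc(S(C)(=O)=O)ccc1Oc1ncnc(OC2CCN(C(=O)OC3(C(F)(F)F)CCC3)CC2)c1F` gives 14.3 nM in this assay. Compound 3 `Cc1nc(S(C)(=O)=O)ccc1Oc1ncnc(OC2CCN(C(=O)SC3CC3)CC2)c1F` gives 24.9 nM in this assay.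

Compound 3 shows the highest of the three numbers, yet all three lie within the scatter of one another, so no order among them can be claimed. Compound 4 `Cc1nc(S(C)(=O)=O)ccc1Oc1ncnc(OC2CCN(C(=O)C(C)(F)F)CC2)c1F` differs from compound 3 in one place: a group of 4 heavy atoms (2 carbon, 2 fluorine; no ring) in place of a group of 4 heavy atoms (3 carbon, 1 sulfur; one three-membered non-aromatic ring of carbon only), on a carbonyl carbon. Two measured steps already vary the group on this same carbonyl carbon, a 1.3-fold higher number from compound 1 to compound 3 (0.10 log units; within the scatter) and a 1.7-fold higher number from compound 2 to compound 3 (0.24 log units; within the scatter), and both stayed within the scatter. A further exchange at this position is therefore expected to give no step beyond the scatter in this assay, a 1.1-fold lower number from compound 3 to compound 4 (0.05 log units; within the scatter). Compound 4 is estimated at 22 nM, with a range from 10 nM to 50 nM.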

Compound 4, half-maximal effective concentration: 37 nM
Estimate against measurement, compound 4: 1.7-fold (0.23 log units) below; low and high end bracket the measured number.
By their numbers in this assay, from the lowest: compounds 2, 1, 3 and 4 (each within the scatter of the next, the first and the last beyond it).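

Going by these compounds alone, the 1,1-difluoroethyl group brings the first step at this carbonyl carbon that lies beyond the scatter in this assay, though a modest one (a 2.6-fold higher number from compound 2 to compound 4 (0.41 log units; beyond the scatter)). The other two new steps stay within the scatter (a 1.5-fold higher number from compound 3 to compound 4 (0.17 log units; within the scatter); a 1.9-fold higher number from compound 1 to compound 4 (0.27 log units; within the scatter)), so this position has now shown a measurable difference in only one of the pairs involving compound 4. No available evidence accounts for this difference. Still open, as far as these compounds go, is how an amine or a longer carbon chain on this carbonyl carbon would read in this assay.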